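Working notes: from compound 2 to compound 4

This account rests on a few compounds, and the source may have more. Where it says the series, first, only, none or still open, it means among the compounds named here.

Measured so far:
- compound 1 `CCOC(=O)C1=Cc2ccccc2OC1(OCc1cc(-c2ccc(F)cc2F)no1)C(F)(F)F` gives > 150000 nM
- compound 2 `CCOC(=O)C1=Cc2ccccc2OC1(OCc1cn(CC(=O)Nc2cccc(Cl)c2)nn1)C(F)(F)F` gives 11600 nM
- compound 3 `CCOC(=O)C1=Cc2ccccc2OC1(OCc1cc(-c2ccc(C)cc2)no1)C(F)(F)F` gives > 150000 nM

Among the measured compounds shown here, in a functional assay on MCF7 cells (Homo sapiens) for inhibition, read by MTT assay, with a stated time of 24 h (on this read-out lower numbers stand for stronger inhibition and higher numbers for weaker inhibition), compound 2 gives 11600 nM, the only number in the set. For compound 1 the value > 150000 nM is a limit of the assay, not a number. For compound 3 the value > 150000 nM is likewise a limit. The step that the two limits leave unreadable from compound 1 to compound 3 therefore cannot be read because both ends sit at the limit of > 150000 nM in this assay, at which 2 of the 3 values shown sit.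

Compound 4 `CCOC(=O)C1=Cc2ccccc2OC1(OCc1cn(CC(=O)NC2CCCCC2)nn1)C(F)(F)F` differs from compound 2 by cyclohexyl in place of 3-chlorophenyl on an amide-type nitrogen. For the measured compounds named here, no measured step touches this position on the shared core; the one pair that differs in a single place, compound 1 and compound 3, is changed elsewhere and gives no readable size. Going by the values given here, there is thus no measured basis for expecting a step in either direction beyond the scatter, and the only anchor is the number for compound 2.

Compound 4 is expected near 20000 nM, between 5000 nM and 90000 nM. The step of a 1.7-fold higher number from compound 2 to compound 4 (0.24 log units; within the scatter) expected here is a placeholder rather than a prediction, and a limit result for compound 4 cannot be ruled out.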

Compound 4, half-maximal inhibitory concentration: 12100 nM
The estimate for compound 4 lay 1.7-fold (0.22 log units) above the measured number; measured number inside the range.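

In this assay, among the compounds shown here, cyclohexyl in place of 3-chlorophenyl on an amide-type nitrogen gives a 1.0-fold higher number from compound 2 to compound 4 (0.02 log units; within the scatter), the first readable step and the first at this position. The two compounds stand within the scatter of each other, so an aromatic ring and a chlorine on this nitrogen's carbon ring are not needed for a readable value in this series. Compound 1 and compound 3 remain limits of the assay, not numbers, and add no size to set beside this step: the limit of > 150000 nM in this assay, at which 2 of the 4 values shown sit.

How far the number can move at this position remains open, since both groups shown are six-membered carbon rings. A short chain such as ethyl, a chain ending in an amine, or a chain ending in a carboxylic acid on this nitrogen would test that.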